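This account rests on a few compounds, and the source may have more. Where it says the series, first, only, none or still open, it means among the compounds named here.

In a functional assay on SK-BR-3 cells (Homo sapiens) for antiproliferative activity, read by MTT assay, with a stated time of 72 h (on this read-out lower numbers stand for stronger inhibition and higher numbers for weaker inhibition), two compounds on a shared core have been tested so far. Compound 1 `C/C=C1/[C@H](O[C@@H]2O[C@H](CO)[C@@H](O)[C@H](O)[C@H]2O)OC=C(C(=O)OC)[C@H]1CC(=O)OCc1ccc2c(c1)OCCO2` gives only a limit, > 15000 nM. Compound 2 `C/C=C1/[C@H](O[C@@H]2O[C@H](COC(C)=O)[C@@H](OC(C)=O)[C@H](OC(C)=O)[C@H]2OC(C)=O)OC=C(C(=O)OC)[C@H]1CC(=O)OCCC1CCCCC1`, which carries 2-cyclohexylethoxy, also gives only a limit, > 15000 nM. Compound 2 therefore has no number that would place it on the scale, and the picture so far is the limit of > 15000 nM in this assay, at which 2 of the 2 values shown sit.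

Compound 3 `C/C=C1/[C@H](O[C@@H]2O[C@H](COC(C)=O)[C@@H](OC(C)=O)[C@H](OC(C)=O)[C@H]2OC(C)=O)OC=C(C(=O)OC)[C@H]1CC(=O)OCC` differs from compound 2 in one place: hydrogen in place of cyclohexyl on a saturated chain carbon, two bonds along the chain from an oxygen next to a carbonyl group. This puts hydrogen in place of cyclohexyl on a saturated chain carbon, two bonds along the chain from an oxygen next to a carbonyl group, so that 2-cyclohexylethoxy becomes ethoxy. Among the compounds with values here, no measured pair shows what such a change does in this assay. The only anchor for an expectation is compound 2, with its limit of > 15000 nM. The expected size of the step that the limit leaves unreadable from compound 2 to compound 3 is none beyond the scatter, with no direction favoured. For compound 3 the estimated value is 20000 nM, with an expected range from 8000 nM to 50000 nM, and the assay may well report only a limit again.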

Compound 3, half-maximal inhibitory concentration: > 15000 nM
Compound 3: no number, only a limit; the forecaster's own chance of this, stated with the estimate: 75%; the middle value does not contradict the limit.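

Compound 3 also gives only a limit in this assay, > 15000 nM. Compound 2 is likewise held at a limit, so the step between compound 2 and compound 3 cannot be read. The compounds shown leave open what any change of group on the shared core does to the read-out, and where any of them stands on the scale: the limit of > 15000 nM in this assay, at which 3 of the 3 values shown sit.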